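This account rests on a few compounds, and the source may have more. Where it says the series, first, only, none or still open, it means among the compounds named here.

Of the compounds shown here, three that share a core have so far been tested in a functional assay on CHO cells for positive allosteric modulation of muscarinic acetylcholine receptor M5 (Homo sapiens), read by FLIPR and calcium flux, with a stated time of 1 h; a higher number here means that more compound is needed for the effect, a lower number that less compound is needed. Compound 1 `O=C1C(=O)N(Cc2ccc(-c3ccccc3)nc2)c2ccc(OC(F)(F)F)cc21` gives 3800 nM. Compound 2 `O=C1C(=O)N(Cc2ccc(-c3cncnc3)cc2)c2ccc(OC(F)(F)F)cc21` gives 2100 nM. Compound 3 `O=C1C(=O)N(Cc2ccc(Br)cc2)c2ccccc21` gives 4600 nM. The numbers of compound 2 and compound 1 lie within the usual scatter of each other, so the two cannot be told apart on this evidence. The number of compound 2 is lower than that of compound 3 by more than the scatter, so less of compound 2 is needed for the effect than of compound 3.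

Compound 4 `O=C1C(=O)N(Cc2ccc(-c3ccccc3)cc2)c2ccc(OC(F)(F)F)cc21` has not yet been measured. It differs from compound 2 in one place: phenyl in place of pyrimidin-5-yl on an aromatic carbon. Among the compounds with values here, no pair of measured compounds shows this exact change, so its effect has no direct precedent. Compound 1 and compound 2 each carry an aromatic ring that contains nitrogen and differ only within the scatter, which suggests that swapping one aromatic ring for another here moves the number little. Compound 4 is therefore expected to give 3000 nM, with a likely range from 1200 nM to 7500 nM. The expected step from compound 2 to compound 4 is a 1.4-fold higher number from compound 2 to compound 4 (0.15 log units; within the scatter), which is no more than a small change that may well sit within the scatter.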

Compound 4, half-maximal effective concentration: 1600 nM
Estimate against measurement, compound 4: 1.9-fold (0.27 log units) above, within the range that was stated.
By their numbers in this assay, from the lowest: compounds 4, 2, 1 and 3 (each within the scatter of the next, the first and the last beyond it).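

Here, on an aromatic carbon para to a large group, the exchange of pyrimidin-5-yl for phenyl in this assay gives a 1.3-fold lower number from compound 2 to compound 4 (0.12 log units; within the scatter). Within the data shown here, this is the first direct comparison of two rings at this position, and it shows that removing the two ring nitrogens, and with them the two hydrogen-bond acceptors, leaves no difference that can be told from the usual scatter. No independent measurement is available that bears on this result.

Going by these compounds, what remains open is whether this position tolerates anything other than a six-membered aromatic ring, since neither compound 2 nor compound 4 shows how an amine or a carboxylic acid would behave there. A single comparison also cannot show whether the same exchange would have as little effect on a different core.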